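The compounds below may be only part of what the source reports. "The series", "measured", "known", "first", "only" and "open" are said of these compounds alone.

Measured so far:
Compound 1, `CCc1nn2c(-c3c(OC)cccc3OC)cccc2c1N(CC1CCOCC1)CC1CC1`: 740 mL.min-1.g-1
Compound 2, `COCc1cc(OC)c(-c2cccc3c(N(CC4CCOCC4)CC4CC4)c(OC)nn23)c(OC)c1`: 760 mL.min-1.g-1

Both compounds were run in an in vitro ADME assay on microsomes from liver (Homo sapiens) for metabolic stability, with a stated time of 15 min; on this read-out higher numbers stand for fast clearance and lower numbers for slow clearance. In this assay compound 1 gives 740 mL.min-1.g-1 and compound 2 gives 760 mL.min-1.g-1; the two numbers lie within the usual scatter of each other, so the two compounds are indistinguishable on this read-out. Compound 2 stands at one end of these two numbers, but only by a margin that the scatter covers. The next compound, compound 3 `CCc1nn2c(-c3c(OC)cc(COC)cc3OC)cccc2c1N(CC1CCOCC1)CC1CC1`, is not yet measured. It differs from compound 2 in one place: ethyl in place of methoxy on an aromatic carbon. Compound 1 already carries an ethyl group on the shared core and gives a clearance indistinguishable from that of compound 2, which carries the methoxy group there. Among the measured compounds shown here, no measured pair isolates this single change, so for compound 3 a step from compound 2 of a 1.0-fold lower number from compound 2 to compound 3 (0.01 log units; within the scatter) is expected, with nothing beyond the scatter. Compound 3 is estimated at 750 mL.min-1.g-1, ranging from 450 mL.min-1.g-1 to 1250 mL.min-1.g-1.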

Compound 3, intrinsic clearance in microsomes: 300 mL.min-1.g-1
Compound 3: middle estimate off by 2.5-fold (0.40 log units), on the high side; measured number below the stated range.
By their numbers in this assay, from the lowest: compound 3; then compounds 1 and 2 (each within the scatter of the next).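

In this assay, ethyl in place of methoxy on an aromatic carbon of the five-membered aromatic ring with 2 nitrogen gives a 2.5-fold lower number from compound 2 to compound 3 (0.40 log units; beyond the scatter) and so shows that the group at this position can change clearance. Methoxymethyl in place of hydrogen on an aromatic carbon gives a 2.5-fold lower number from compound 1 to compound 3 (0.39 log units; beyond the scatter) as a second change that lowers the number. Neither change could be read from the first two compounds alone, since those differ in more than one place, whereas each of these steps isolates a single change.

Nothing measured here explains why either change lowers clearance.
Also open, on these data alone, is how a longer chain such as propyl, or an amine or a carboxylic acid, would fare at the ethyl position.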